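This account rests on a few compounds, and the source may have more. Where it says the series, first, only, none or still open, it means among the compounds named here.

Compound 3 `CC(C)(C)Cc1c(-c2cc(F)ccc2F)sc(N)c1C(=O)c1ccc(Cl)cc1` gives 1% in an assay on CHO cells for displacement of a labelled ligand from adenosine receptor A3 (Homo sapiens), read by scintillation counting, tested at 10 uM; a lower number here means less inhibition, a higher number more inhibition at the concentration tested (going by the name of the read-out). Compound 1 `CC(C)(C)Cc1csc(N)c1C(=O)c1ccc(Cl)cc1` gives 5% in this assay, and compound 2 `CC(C)(C)Cc1c(-c2cccc(F)c2F)sc(N)c1C(=O)c1ccc(Cl)cc1` gives 1%; all three numbers lie within the scatter of one another, so none stands apart. The steps of a number 4 percentage points lower from compound 1 to compound 3 (within the scatter) and no change at the digits printed from compound 2 to compound 3 (within the scatter) are both within the scatter, as is a number 4 percentage points lower from compound 1 to compound 2 (within the scatter). Compound 4 `CC(C)(C)Cc1c(-c2ccc(Cl)cc2)sc(N)c1C(=O)c1ccc(Cl)cc1` differs from compound 3 by 4-chlorophenyl in place of 2,5-difluorophenyl on an aromatic carbon. Adding an aryl group to compound 1 moved nothing beyond the scatter, and swapping one aryl group for another moved nothing either, so the expected step here is a number 2 percentage points higher from compound 3 to compound 4 (within the scatter), again within the scatter. Compound 4 is therefore estimated at 3%, with a range from -6% to 13%.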

Compound 4, a percentage reported as inhibition, at one concentration (the size of the read-out at that concentration, not a potency): 1%
Estimate against measurement, compound 4: 2 percentage points above; the range from low to high includes it.
By their numbers in this assay, from the lowest: compounds 2, 3, 4 and 1 (each within the scatter of the next).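

With a single chlorine in place of two fluorines, the aryl group next to the ring sulfur still gives no change at the digits printed from compound 3 to compound 4 (within the scatter) and no change at the digits printed from compound 2 to compound 4 (within the scatter) in this assay, so a third aryl pattern reads like the first two. Set against hydrogen at this position, 4-chlorophenyl gives a number 4 percentage points lower from compound 1 to compound 4 (within the scatter), so no aryl group shown here separates from hydrogen. Nothing available explains why these numbers sit together.

Open, as far as these compounds go, is whether an amine or a carboxylic acid at this position would give a number beyond the scatter. Also open, from the compounds shown here alone, is whether replacing the neopentyl group, which all four compounds share, would change the reading.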